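This account rests on a few compounds, and the source may have more. Where it says the series, first, only, none or still open, it means among the compounds named here.

In a functional assay on HUVEC cells (Homo sapiens) for inhibition (a higher number here means a weaker inhibitor, a lower number a stronger inhibitor), two compounds built on the same core have been measured so far. Compound 1, `CN(c1ccc(NC(=N)Nc2ccccc2)cc1)c1ccnc(Nc2cccc(CS(C)(=O)=O)c2)n1`, gives 596 nM, while compound 2, `CN(c1ccc(NC(=O)Nc2ccc(OC(F)(F)F)cc2)cc1)c1ccnc(Nc2cccc(CS(C)(=O)=O)c2)n1`, gives 7 nM. Compound 2 therefore holds the lower of the two numbers, and its gap to compound 1 lies well beyond the scatter. These two compounds differ in more than one place, so the gap cannot be assigned to any single group.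

Compound 3, `CN(c1ccc(NC(=O)Nc2c(Cl)cccc2Cl)cc1)c1ccnc(Nc2cccc(CS(C)(=O)=O)c2)n1`, departs from compound 2 in one place only: 2,6-dichlorophenyl in place of 4-(trifluoromethoxy)phenyl on an amide-type nitrogen. In words, 2,6-dichlorophenyl stands in place of 4-(trifluoromethoxy)phenyl on an amide-type nitrogen. Going by the values given here, no measured pair tests this exchange, so any forecast is uncertain. Since compound 2 sits at the low end with 7 nM, a move toward a higher number in this assay, meaning a weaker inhibitor, seems more likely than a further fall, and it is expected to lie modestly beyond the scatter. The expected change is a 5.0-fold higher number from compound 2 to compound 3 (0.70 log units; beyond the scatter). Compound 3 is estimated at 35 nM, with an expected range of 8 nM to 160 nM.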

Compound 3, half-maximal inhibitory concentration: 29 nM
Compound 3: the middle estimate sits 1.2-fold (0.08 log units) above what was measured; low and high end bracket the measured number.
By their numbers in this assay, from the lowest: compound 2; then compound 3; then compound 1.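

Going by these compounds alone, the exchange of 4-(trifluoromethoxy)phenyl for 2,6-dichlorophenyl on an amide-type nitrogen gives the first single-place reading at this position in this assay: a 4.1-fold higher number from compound 2 to compound 3 (0.62 log units; beyond the scatter), a modest step that leaves compound 3 29 nM, still a good deal stronger than compound 1. This shows that two quite different substituted phenyl groups can stand at this position with only a modest change in the number, while the replacement of the whole group on the aromatic nitrogen gives a large step, a 21-fold lower number from compound 1 to compound 3 (1.31 log units; beyond the scatter). Nothing available explains either step.

The large step changes the carbonyl and the ring substituents together, so the compounds shown cannot say how much of it belongs to each; a phenyl group on the carbonyl-bearing linker would separate the two. From the compounds shown here alone, whether the aromatic ring is needed at all also stays open, as does how a cyclohexyl group or a simple methyl group would fare on the same amide-type nitrogen in this assay.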